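The source may hold more compounds than are shown below. What is called first, only, known or untested is meant among the compounds shown, and "the series" means these compounds.

For the measured compounds named here, compound 2 `CN(C)CCNc1nc(-c2ccc(NC(=O)Nc3ccc(Cl)cc3)cc2)nc2c(Cl)c(Cl)sc12` stands with the lower of the two numbers measured so far: in a functional assay on MKN-45 cells (Homo sapiens) for cytotoxicity, read by MTT assay, with a stated time of 72 h (on this read-out lower numbers stand for stronger inhibition and higher numbers for weaker inhibition), compound 2 gives 910 nM, while compound 1 `CN(C)CCCNc1nc(-c2ccc(NC(=O)Nc3ccc(Cl)cc3Cl)cc2)nc2c(Cl)c(Cl)sc12`, which differs from it in several places, gives 2560 nM, a gap beyond the usual scatter. Compound 3 `CN(C)CCNc1nc(-c2ccc(NC(=O)Nc3ccc(Cl)cc3Cl)cc2)nc2c(Cl)c(Cl)sc12` arises from compound 2 by one change, (chloro in place of hydrogen on an aromatic carbon). Going by the values given here, no measured pair isolates this change, so its effect is unknown from the data. Compound 3 is expected to give a number somewhat above that of compound 2, an expected step of a 1.6-fold higher number from compound 2 to compound 3 (0.22 log units; within the scatter), and an estimated value of 1500 nM, within 600 nM to 4000 nM.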

Compound 3, half-maximal inhibitory concentration: 3460 nM
The estimate for compound 3 lay 2.3-fold (0.36 log units) below the measured number; low and high end bracket the measured number.
By their numbers in this assay, from the lowest: compound 2; then compounds 1 and 3 (each within the scatter of the next).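

In this assay, for the compounds shown here, chloro in place of hydrogen on an aromatic carbon, which turns 4-chlorophenyl into 2,4-dichlorophenyl, weakens inhibition, with a 3.8-fold higher number from compound 2 to compound 3 (0.58 log units; beyond the scatter) as the first single-change reading at this position. Dimethylamino in place of (dimethylamino)methyl on a saturated chain carbon gives a 1.4-fold higher number from compound 1 to compound 3 (0.13 log units; within the scatter) and so shows no separable effect of chain length with the 2,4-dichlorophenyl group in place. Nothing measured here accounts for the chloro step.

From the compounds shown here alone, whether fluoro, methyl or methoxy on this carbon would give a similar step remains open. So does whether the chloro step would hold with the longer chain of compound 1.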